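Ring-nitrogen aryl substituents on a fixed sulfonamide core

The source may report more compounds than this note shows. Statements on the series, on what has been measured and on what is new or still open speak of the compounds shown alone.

Three measured analogues share one core and differ only in the group on the ring nitrogen: compound 1 `CCCn1c(=O)[nH]c2nc(-c3ccc(S(=O)(=O)N4CCN(c5ccc(F)cc5)CC4)cc3)[nH]c2c1=O`, compound 2 `CCCn1c(=O)[nH]c2nc(-c3ccc(S(=O)(=O)N4CCN(c5ccccc5C)CC4)cc3)[nH]c2c1=O` and compound 3 `CCCn1c(=O)[nH]c2nc(-c3ccc(S(=O)(=O)N4CCN(c5ccccc5)CC4)cc3)[nH]c2c1=O`. In an assay on CHO cells for displacement of a labelled ligand from adenosine receptor A2b (Homo sapiens), read by scintillation counting, with a stated time of 75 min, in the presence of a further agent that is not named here (a lower number here means a stronger inhibitor, a higher number a weaker inhibitor), compound 1 gives 0.644 nM, compound 2 gives 0.432 nM and compound 3 gives 0.643 nM. Compound 2 sits alongside the other two, since a 1.5-fold lower number from compound 1 to compound 2 (0.17 log units; within the scatter) and a 1.5-fold higher number from compound 2 to compound 3 (0.17 log units; within the scatter) both fall within the scatter, as does a 1.0-fold lower number from compound 1 to compound 3 (0.00 log units; within the scatter). Compound 4 `CCCn1c(=O)[nH]c2nc(-c3ccc(S(=O)(=O)N4CCN(Cc5ccc(Br)cc5)CC4)cc3)[nH]c2c1=O` carries 4-bromobenzyl in place of 2-methylphenyl on an amine nitrogen in a ring. For the measured compounds named here, the steps that bear on this change are a 1.5-fold lower number from compound 1 to compound 2 (0.17 log units; within the scatter) and a 1.5-fold higher number from compound 2 to compound 3 (0.17 log units; within the scatter), neither beyond the scatter, though no measured step replaces an aryl with a benzyl group, so uncertainty is wider. The expected step is a 1.3-fold higher number from compound 2 to compound 4 (0.10 log units; within the scatter), none beyond the scatter. Compound 4 is therefore estimated at 0.55 nM, expected between 0.18 nM and 1.7 nM.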

Compound 4, inhibition constant: 0.153 nM
For compound 4 the middle estimate is 3.6-fold (0.56 log units) above the measured one; measured number below the stated range.
By their numbers in this assay, from the lowest: compound 4; then compounds 2, 3 and 1 (each within the scatter of the next).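

Notes on the amine nitrogen in the ring: in this assay, 4-bromobenzyl is the first group here to move the number beyond the scatter, with modest steps to all three aryl compounds (a 2.8-fold lower number from compound 2 to compound 4 (0.45 log units; beyond the scatter); a 4.2-fold lower number from compound 3 to compound 4 (0.62 log units; beyond the scatter); a 4.2-fold lower number from compound 1 to compound 4 (0.62 log units; beyond the scatter)). The three aryl groups stay within the scatter of one another, so this position is not insensitive to change, and compound 4 stands lowest of the four. No measured evidence accounts for this step.

Open, on these data alone, is whether the benzyl link or the bromine carries the step: unsubstituted benzyl would separate the two. As far as these compounds go, a longer chain, such as phenethyl, also remains open.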